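Cytotoxicity notes: acylating the aniline nitrogen of compound 3

This account rests on a few compounds, and the source may have more. Where it says the series, first, only, none or still open, it means among the compounds named here.

Compound 3 `Cn1c(-c2ccc(N)cc2)nc2cc(C(F)(F)F)ccc21` is the unsubstituted aniline of the series. In an ADME assay on MDBK cells (Bos taurus) for cytotoxicity, read by MTT assay, with a stated time of 96 h (on this read-out higher numbers stand for lower toxicity in this test and lower numbers for higher toxicity in this test), compound 3 gives 74000 nM, the highest of the three numbers measured. Its nearest neighbour is compound 1 `CN1CCN(CC(=O)Nc2ccc(-c3nc4cc(C(F)(F)F)ccc4n3C)cc2)CC1`, which in this assay gives 44000 nM; compound 2 `O=C(CN1CCCC1)Nc1ccc(-c2nc3cc(C(F)(F)F)ccc3[nH]2)cc1`, which carries a differently substituted core, gives 15000 nM in this assay, the lowest of the three.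

The step to compound 4 `Cn1c(-c2ccc(NC(=O)CN3CCCC3)cc2)nc2cc(C(F)(F)F)ccc21` is ((pyrrolidin-1-yl)methyl)carbonyl in place of hydrogen on a nitrogen on an aromatic ring. Among the compounds with values here, the one measured step that bears on it is the reverse of this kind of change: a 1.7-fold higher number from compound 1 to compound 3 (0.23 log units; within the scatter). Removing an amide substituent of comparable size from the same nitrogen therefore moved the read-out very little. Compound 2 shares the ((pyrrolidin-1-yl)methyl)carbonyl group of compound 4 but sits on a different core, so its lower number cannot be attributed to the acyl group alone; it is noted only as the lowest value in the set.

On this basis the expected change in this assay from compound 3 is small, at most a modest drop toward the range of compound 1, a 2.5-fold lower number from compound 3 to compound 4 (0.39 log units; beyond the scatter). Compound 4 is estimated at 30000 nM in this assay, with a likely range from 12000 nM to 75000 nM.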

Compound 4, half-maximal cytotoxic concentration: 65000 nM
Compound 4: middle estimate off by 2.2-fold (0.34 log units), on the low side, and the stated range covers the measured number.
By their numbers in this assay, from the lowest: compound 2; then compounds 1, 4 and 3 (each within the scatter of the next).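

In this assay the ((pyrrolidin-1-yl)methyl)carbonyl group on the nitrogen on an aromatic ring leaves the number within the scatter of the free amino compound (a 1.1-fold lower number from compound 3 to compound 4 (0.06 log units; within the scatter)), and pyrrolidin-1-yl in place of 4-methylpiperazin-1-yl on the saturated chain carbon bound to a carbonyl carbon also stays within the scatter (a 1.5-fold higher number from compound 1 to compound 4 (0.17 log units; within the scatter)). Within the data shown here, the only new step beyond the scatter lies at another place, methyl in place of hydrogen on an aromatic nitrogen (a 4.3-fold higher number from compound 2 to compound 4 (0.64 log units; beyond the scatter)), so within these compounds the low number of compound 2 goes with the hydrogen on that aromatic nitrogen and not with the acyl group. Nothing available bears on why the read-out follows this pattern.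

From the compounds shown here alone, whether the amide nitrogen stays this insensitive with a simple acetyl group, a longer chain before the pyrrolidin-1-yl ring or a carboxylic acid on the chain remains open. Going by these compounds, it is also open whether the step at the aromatic nitrogen recurs with 4-methylpiperazin-1-yl on the chain or with an ethyl group in place of methyl.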